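Swapping chloro for methyl on a pyrazole aniline series

The source may hold more compounds than are shown below. What is called first, only, known or untested is meant among the compounds shown, and "the series" means these compounds.

Measured compounds:
- compound 1 `Cc1ccc(-c2nn(-c3ccccc3)cc2CNc2ccccc2)cc1`: 52000 nM
- compound 2 `FC(F)(F)c1ccc(NCc2cn(-c3ccccc3)nc2-c2ccc(Br)cc2)cc1`: 28000 nM
- compound 3 `Clc1ccc(NCc2cn(-c3ccccc3)nc2-c2ccc(Cl)cc2)cc1`: 90000 nM

All three compounds share a core in which a phenyl-bearing pyrazole carries a second aryl ring and a methylene-linked aniline. They were tested in an ADME assay on Vero 76 cells (Chlorocebus sabaeus) for cytotoxicity, read by MTT assay, with a stated time of 96 h; a lower number here means that less compound is tolerated, a higher number that more compound is tolerated. Compound 3 gives the highest of the three numbers, 90000 nM. Its nearest neighbour is compound 1, whose 52000 nM sits within the scatter of compound 3, so no order between the two can be read. Compound 2, at 28000 nM, lies beyond the scatter and is tolerated less well than compound 3.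

The next compound, compound 4 `Cc1ccc(NCc2cn(-c3ccccc3)nc2-c2ccc(Cl)cc2)cc1`, differs from compound 3 in one place: methyl in place of chloro on an aromatic carbon. Among the measured compounds shown here, no measured pair shows this change, so its effect is unknown. Because compound 3 sits at 90000 nM and compound 1 at 52000 nM differ only within the scatter despite different substituents, the step of a 1.3-fold lower number from compound 3 to compound 4 (0.11 log units; within the scatter) is expected to stay small, with no clear direction beyond the scatter. Compound 4 is therefore estimated at 70000 nM, with a range from 30000 nM to 160000 nM.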

Compound 4, half-maximal cytotoxic concentration: > 100000 nM
Compound 4: only a limit was reported; the forecaster's own chance of this, stated with the estimate: 15%; at least 1.4-fold (0.15 log units) between middle value and limit.
By their numbers in this assay, from the lowest: compounds 2, 1 and 3 (each within the scatter of the next, the first and the last beyond it). At a limit, above all of these: compound 4.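

Compound 4 gives > 100000 nM, which is a limit of the assay and not a number. In this assay, among the compounds shown here, going from (4-chlorophenyl)amino to (4-methylphenyl)amino gives an at least 1.1-fold higher number from compound 3 to compound 4 (0.04 log units; that floor lies within the scatter), so this is the first direct look at this change, and it shows no fall in the number at this position. How large the step really is remains hidden behind that limit: the limit of > 100000 nM in this assay, at which 1 of the 4 values shown sits.

The compounds shown leave open how this position responds to groups other than chloro, methyl and trifluoromethyl, such as a methoxy group, an amine or a carboxylic acid. On these data alone, it also remains open whether methyl in place of chloro on the other aryl ring of the shared core would give a similar step.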